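Diethylamide with thiophen-2-yl: expected binding at one concentration

The compounds below may be only part of what the source reports. "The series", "measured", "known", "first", "only" and "open" are said of these compounds alone.

Of the compounds shown here, three have been measured in an assay on membranes from HeLa cells for displacement of a labelled ligand from adenosine receptor A3 (Homo sapiens), read by scintillation counting, with a stated time of 180 min, tested at 1 uM; a higher number here means more inhibition at the concentration tested (going by the name of the read-out), a lower number less inhibition. Compound 1 `CCCOC(=O)C1=C(C)NC(=O)NC1c1cccs1` gives 32%, compound 2 `CCCC(=O)C1=C(C)NC(=O)NC1c1cccs1` gives 2%, and compound 3 `CCN(CC)C(=O)C1=C(C)NC(=O)NC1c1ccoc1` gives 37%. Compound 3 stands highest of the three numbers, though its nearest neighbour, compound 1, lies within the scatter of it, so no order between these two can be claimed; compound 2 lies furthest from it, beyond the scatter. For the measured compounds named here, the only step between measured compounds that differ in one place is a number 30 percentage points lower from compound 1 to compound 2 (beyond the scatter), which concerns the group on the carbonyl carbon and not the aromatic ring.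

Compound 4 `CCN(CC)C(=O)C1=C(C)NC(=O)NC1c1cccs1` is not yet measured. It differs from compound 3 by thiophen-2-yl in place of furan-3-yl on a saturated ring carbon. Going by the values given here, no measured pair isolates this exchange of the five-membered aromatic ring, so no step bears on it directly. What can be said is that compound 1, which already carries thiophen-2-yl, and compound 3, which carries furan-3-yl, give numbers within the scatter of each other in this assay. The step is therefore expected to be a number 2 percentage points lower from compound 3 to compound 4 (within the scatter), that is, none beyond the scatter. Compound 4 is estimated at 35%, with a range from 15% to 55%.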

Compound 4, a percentage reported as inhibition, at one concentration (the size of the read-out at that concentration, not a potency): 31%
Compound 4: the middle estimate sits 4 percentage points above what was measured; the measured number falls inside the stated range.
By their numbers in this assay, from the lowest: compound 2; then compounds 4, 1 and 3 (each within the scatter of the next).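

In this assay, for the compounds shown here, thiophen-2-yl in place of furan-3-yl on the saturated ring carbon gives a number 6 percentage points lower from compound 3 to compound 4 (within the scatter) and thus offers the first direct reading of this exchange, which shows that the two rings cannot be told apart here when diethylamino sits on the carbonyl carbon. With thiophen-2-yl held fixed, diethylamino in place of propyl gives a number 29 percentage points higher from compound 2 to compound 4 (beyond the scatter) and diethylamino in place of propoxy gives a number 1 percentage points lower from compound 1 to compound 4 (within the scatter) so that, of the three groups on the carbonyl carbon, diethylamino and propoxy cannot be separated while propyl alone stands apart. Nothing available explains either result, whether the lack of separation between the two rings or the separate place of propyl.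

From the compounds shown here alone, it remains open whether a phenyl ring on the saturated ring carbon would stay level with thiophen-2-yl and furan-3-yl, and whether a piperidine amide or a longer ester chain on the carbonyl carbon would fall with diethylamino and propoxy or with propyl. The read-out also comes from a single concentration, so compounds that cannot be told apart here may still differ in potency.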